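The source may hold more compounds than are shown below. What is called first, only, known or untested is meant among the compounds shown, and "the series" means these compounds.

Among the measured compounds shown here, in a functional assay on A549 cells (Homo sapiens) for cytotoxicity, read by MTT assay, with a stated time of 48 h (on this read-out lower numbers stand for stronger inhibition and higher numbers for weaker inhibition), compound 1 (`C=CCn1c(-c2cc(OC)c(OC)cc2COCOC)cc2ccccc2c1=O`) gives 88100 nM as the highest of three numbers so far, which makes it the weakest of the three. Compound 2 (`C=CCn1c(-c2cc(OC)c(OC)cc2C=C)cc2ccccc2c1=O`) gives 43200 nM and compound 3 (`COc1ccc2c(c1)C=CCn1c-2cc2ccccc2c1=O`) gives 6480 nM as the number furthest from compound 1. Not yet measured is compound 4 (`COCOCc1cc(OC)c(OC)cc1-c1cc2ccccc2c(=O)[nH]1`), which has hydrogen in place of allyl on an aromatic nitrogen. For the measured compounds named here, the only measured step in one place (a 2.0-fold lower number from compound 1 to compound 2 (0.31 log units; beyond the scatter)) is modest and puts vinyl in place of (methoxymethoxy)methyl on an aromatic carbon. That is a different place, so it bears on this change only weakly. Going by the values given here, no measured compound has hydrogen on that nitrogen, so the data give no direction, and no step beyond the scatter is expected in this assay for this change. The expected step is small (a 1.2-fold lower number from compound 1 to compound 4 (0.07 log units; within the scatter)) and could turn out either way. Compound 4 is therefore expected at 75000 nM within a wide range of 30000 nM to 180000 nM in this estimate.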

Compound 4, half-maximal inhibitory concentration: 85100 nM
Compound 4: the middle estimate sits 1.1-fold (0.05 log units) below what was measured; measured number inside the range.
By their numbers in this assay, from the lowest: compound 3; then compounds 2, 4 and 1 (each within the scatter of the next, the first and the last beyond it).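

Among the compounds shown here, putting hydrogen in place of allyl on the aromatic nitrogen gives a 1.0-fold lower number from compound 1 to compound 4 (0.02 log units; within the scatter) in this assay, and this is the first measured change at that position. For this pair, the allyl group, with its 3 carbons and its double bond, is therefore not needed to keep the number that compound 1 gives, and the two groups cannot be told apart here. Nothing measured explains why this change leaves the number where it is.

Going by these compounds, it remains open whether a methyl group, a longer alkyl chain or a chain ending in an amine on that nitrogen would also leave the number in place. On these data alone, it is equally open whether hydrogen there would behave the same way in a compound carrying the vinyl group of compound 2.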